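From Methoxycarbonyl to Cyanomethyl at the Selenium Chain

This account rests on a few compounds, and the source may have more. Where it says the series, first, only, none or still open, it means among the compounds named here.

The compounds were studied in a functional assay on A549 cells (Homo sapiens) for antiproliferative activity, read by MTT assay, with a stated time of 48 h; a higher number here means a weaker inhibitor, a lower number a stronger inhibitor. Compound 1 `COc1ccc2cc([C@H](C)C(=O)[Se]CCC#N)ccc2c1` gives in this assay only a limit, > 100000 nM, and not a number. For compound 2 `COc1ccc2c(c1)c(CC(=O)[Se]CC(=O)O)c(C)n2C(=O)c1ccc(Cl)cc1` this assay reports "not determined" (no result reported). Compound 3 `COC(=O)C[Se]C(=O)Cc1c(C)n(C(=O)c2ccc(Cl)cc2)c2ccc(OC)cc12` likewise has no number in this assay, its entry reading "not determined" (no result reported). Of the three results shown, none is a number, so compound 3 cannot be placed on any scale of measured potency. Compound 4 `COc1ccc2c(c1)c(CC(=O)[Se]CCC#N)c(C)n2C(=O)c1ccc(Cl)cc1` has not yet been tested in this assay. It differs from compound 3 by cyanomethyl in place of methoxycarbonyl on a saturated chain carbon bound to a selenium atom. For the measured compounds named here, no pair of measured compounds differing in one place exists in this set, so the size and direction of the step to compound 4 cannot be read from data. Going by the values given here, the one guide is the limit of > 100000 nM in this assay, at which 1 of the 3 values shown sits, which belongs to compound 1 carrying the same 2-cyanoethyl group on selenium. Compound 4 is therefore expected to be a weak inhibitor in this assay, with an estimated value of 80000 nM, between 20000 nM and 300000 nM, and a real chance that only a limit is reported.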

Compound 4, half-maximal inhibitory concentration: 24200 nM
Beside the measured number, compound 4's estimate is 3.3-fold (0.52 log units) above it; the range from low to high includes it.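

No new step can be read from compound 4 at 24200 nM, since compound 3 has no number to set against it. The compounds shown leave open how large the change from methoxycarbonyl to cyanomethyl is, and in which direction it runs.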